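The source may report more compounds than this note shows. Statements on the series, on what has been measured and on what is new or still open speak of the compounds shown alone.

Compound 3 `O=C(Nc1ccc2nc(NC(=O)C3CC3)sc2c1)c1c(Cl)cccc1Cl` gives the lowest number of the three in a functional assay on WI-38 VA13 cells (Homo sapiens) for cytotoxicity (a higher number here means that more compound is needed for the effect, a lower number that less compound is needed), at 0.013 ug/mL. Among the measured compounds shown here, compound 2 `C=CCOC(=O)Nc1ccc2nc(NC(=O)C3CCCCC3)sc2c1` gives 0.58 ug/mL, and compound 1 `N#Cc1ccc(C(=O)Nc2ccc3nc(NC(=O)C4CCCCC4)sc3c2)cc1` gives 3.3 ug/mL; the one single-place step measured, a 5.7-fold lower number from compound 1 to compound 2 (0.76 log units; beyond the scatter), concerns a different carbonyl carbon from the one changed here. Compound 4 `CCCCCCNC(=O)Nc1nc2ccc(NC(=O)c3c(Cl)cccc3Cl)cc2s1` differs from compound 3 by hexylamino in place of cyclopropyl on a carbonyl carbon. For the measured compounds named here, no measured step touches this place, and the pair of compound 3 against compounds 1 and 2 has no step of its own, so that step between compound 1 and compound 2 is the only guide to how far a change at a carbonyl carbon shifts this assay. Compound 4 is therefore expected to give a somewhat higher number, about 0.05 ug/mL (range 0.008 ug/mL to 0.3 ug/mL), a step of a 3.8-fold higher number from compound 3 to compound 4 (0.59 log units; beyond the scatter).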

Compound 4, half-maximal effective concentration: 0.29 ug/mL
Compound 4: the middle estimate sits 5.8-fold (0.76 log units) below what was measured, and the stated range covers the measured number.
By their numbers in this assay, from the lowest: compound 3; then compounds 4 and 2 (each within the scatter of the next); then compound 1.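

Exchanging cyclopropyl for hexylamino on this carbonyl carbon gives a 22-fold higher number from compound 3 to compound 4 (1.35 log units; beyond the scatter) in this assay, which shows that this place, untouched by the earlier step, also moves the number. That step is large, whereas a 5.7-fold lower number from compound 1 to compound 2 (0.76 log units; beyond the scatter) at the other carbonyl carbon is modest. Nothing measured here explains the size of the step.

The change removes the ring and adds the amino nitrogen together, so the compounds shown leave open which of the two carries the step. A plain hexyl or a cyclopropylamino group at this place would separate them.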